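Sulfonyl replacement on the amine nitrogen of compound 1

This account rests on a few compounds, and the source may have more. Where it says the series, first, only, none or still open, it means among the compounds named here.

The series shares one core bearing a substituted amine nitrogen, tested in an assay on brain for displacement of a labelled ligand from D(3) dopamine receptor (Rattus norvegicus); a higher number here means a weaker inhibitor, a lower number a stronger inhibitor. Compound 1 `CCCN(CC[C@H]1CC[C@H](NC(=O)/C=C/c2ccc(Cl)cc2)CC1)[C@H]1CCc2nc(N)sc2C1` gives 2.5 nM. Compound 2 `CCCN(CC[C@H]1CC[C@H](NC(=O)c2ccc3ccccc3n2)CC1)[C@H]1CCc2nc(N)sc2C1` gives 1.6 nM, and compound 3 `CCCN(CC[C@H]1CC[C@H](NC(=O)c2cccc(-n3cncn3)c2)CC1)[C@H]1CCc2nc(N)sc2C1` gives 3 nM. Compound 1 stands second highest of the three numbers, with a 1.6-fold lower number from compound 1 to compound 2 (0.19 log units; within the scatter) and a 1.2-fold higher number from compound 1 to compound 3 (0.08 log units; within the scatter); between the other two, a 1.9-fold higher number from compound 2 to compound 3 (0.27 log units; within the scatter). Among the measured compounds shown here, all three steps lie within the scatter, so nothing among the measured compounds separates from the rest.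

Compound 4 `CCCN(CC[C@H]1CC[C@H](NS(=O)(=O)c2ccc(Cl)nc2)CC1)[C@H]1CCc2nc(N)sc2C1` is not yet measured. It differs from compound 1 by (6-chloropyridin-3-yl)sulfonyl in place of (2-(4-chlorophenyl)ethenyl)carbonyl on an amine nitrogen. For the measured compounds named here, the measured steps bear only loosely on this: each exchanged one carbonyl-linked group for another and stayed within the scatter, whereas here the carbonyl itself gives way to a sulfonyl, a change no measured pair covers. Going by the values given here, with the group variation so far staying within the scatter, the expectation for compound 4 is a modest weakening, a 3.2-fold higher number from compound 1 to compound 4 (0.51 log units; beyond the scatter). Among the compounds with values here, no measured step tests the linker, so the range is kept wide. The estimated value for compound 4 is 8 nM, expected to fall between 2 nM and 40 nM.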

Compound 4, inhibition constant: 0.63 nM
For compound 4 the middle estimate is 13-fold (1.10 log units) above the measured one; the whole stated range lies above it.
By their numbers in this assay, from the lowest: compound 4; then compounds 2, 1 and 3 (each within the scatter of the next).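

In this assay, among the compounds shown here, the exchange on the amine nitrogen gives a 4.0-fold lower number from compound 1 to compound 4 (0.60 log units; beyond the scatter), the first step to lie beyond the scatter, whereas the carbonyl-linked exchanges all stayed within it. The position therefore accepts a sulfonyl-linked group in place of the carbonyl-linked one without loss, but the linker and the aromatic group change together, so the lower number cannot be assigned to the sulfonyl or to the 6-chloropyridine alone. Nothing available accounts for the size of this step.

Open, on these data alone, is whether a 4-chlorophenyl group on the sulfonyl keeps the lower number, which would separate the linker from the ring. Also open, as far as these compounds go, is whether a small alkyl group such as methyl on the sulfonyl does the same.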